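This account rests on a few compounds, and the source may have more. Where it says the series, first, only, none or still open, it means among the compounds named here.

In a functional assay on A549 cells (Homo sapiens) for cytotoxicity, read by MTT assay, with a stated time of 72 h (on this read-out higher numbers stand for weaker inhibition and lower numbers for stronger inhibition), compound 1 (`COc1cccc(/C=C2\CCC/C(=C\c3ccc(OC)c(OC)c3)C2=O)c1`) gives 6700 nM, compound 2 (`COc1ccc(/C=C2\CCC/C(=C\c3ccc(OC)c(OC)c3)C2=O)cc1OC`) gives 8500 nM and compound 3 (`COc1cc(/C=C2\CCC/C(=C\c3ccc(OC)c(OC)c3)C2=O)cc(OC)c1`) gives 5100 nM, so compound 1 lies within the scatter of both others. Compound 4 (`COc1ccc(/C=C2\CCC/C(=C\c3ccc(O)c(Cl)c3)C2=O)cc1OC`) has not yet been measured. It carries 3-chloro-4-hydroxyphenyl in place of 3-methoxyphenyl on a double-bonded chain carbon bound to a double-bonded ring carbon. The nearest evidence is two methoxy-for-hydrogen steps, a 1.3-fold higher number from compound 1 to compound 2 (0.10 log units; within the scatter) and a 1.3-fold lower number from compound 1 to compound 3 (0.12 log units; within the scatter). For the measured compounds named here, neither tests chlorine or hydroxy, since no measured compound carries them, so the range stays wide. In this assay, the expected step, a 1.5-fold lower number from compound 1 to compound 4 (0.17 log units; within the scatter), is no larger than the scatter. For compound 4 the estimate is 4500 nM, with an expected range of 1500 nM to 12000 nM.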

Compound 4, half-maximal inhibitory concentration: > 20000 nM
Compound 4 gave a limit, no number; the forecaster's own chance of this, stated with the estimate: 3%; middle value at least 4.4-fold (0.64 log units) from the limit.
By their numbers in this assay, from the lowest: compounds 3, 1 and 2 (each within the scatter of the next). At a limit, above all of these: compound 4.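

In this assay, replacing 3-methoxyphenyl with 3-chloro-4-hydroxyphenyl gives an at least 2.9-fold higher number from compound 1 to compound 4 (0.47 log units; beyond the scatter), so this place on a double-bonded chain carbon bound to a double-bonded ring carbon responds to change, whereas the methoxy-for-hydrogen steps stayed within the scatter. Compound 4 gives a limit, not a number: the limit of > 20000 nM in this assay, at which 1 of the 4 values shown sits.

The compounds shown do not separate the chlorine from the hydroxy, since both enter together, and the full size of the step stays unknown. They also leave open how an amine or a carboxylic acid would behave at this place.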